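Notes on the amide ring change from compound 2 to compound 3

The source may report more compounds than this note shows. Statements on the series, on what has been measured and on what is new or still open speak of the compounds shown alone.

Two compounds of the series have numbers in an assay on isolated protein for inhibition of thyroid hormone receptor beta (Homo sapiens), read by fluorescence, with a stated time of 30 min; a higher number here means a weaker inhibitor, a lower number a stronger inhibitor. Compound 1 `CCCc1cc(C(=O)N(CCC)CC2CCOC2)cc2nc(NCc3cccc(Cl)c3)oc12` gives 957 nM. Compound 2 `COc1cc(C(=O)N2CCCC2)cc2nc(NCc3cccc(Cl)c3)oc12` gives 180 nM, the lowest of the two values, and the gap from compound 1 lies beyond the scatter. The two differ in more than one place, so their values stand side by side without a counted step.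

Compound 3 `COc1cc(C(=O)N2CCC(O)C(C)C2)cc2nc(NCc3cccc(Cl)c3)oc12` has not yet been measured in this assay. It departs from compound 2 by 4-hydroxy-3-methylpiperidin-1-yl in place of pyrrolidin-1-yl on a carbonyl carbon. Going by the values given here, no measured pair isolates this change at the carbonyl carbon. The step of a 1.7-fold higher number from compound 2 to compound 3 (0.22 log units; within the scatter) is therefore an estimate only. A modest weakening, or no change beyond the scatter, is expected. For compound 3 the estimated value in this assay is 300 nM, with a range from 100 nM to 900 nM.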

Compound 3, half-maximal inhibitory concentration: 25 nM
Estimate against measurement, compound 3: 12-fold (1.08 log units) above, and the stated range ends above it.
By their numbers in this assay, from the lowest: compound 3; then compound 2; then compound 1.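

In this assay, going by these compounds alone, the group on the carbonyl carbon has a clear bearing on the number: 4-hydroxy-3-methylpiperidin-1-yl in place of pyrrolidin-1-yl gives a 7.2-fold lower number from compound 2 to compound 3 (0.86 log units; beyond the scatter), the first counted step. The position therefore accepts a six-membered ring of 8 heavy atoms, carrying a hydrogen-bond donor and acceptor that pyrrolidin-1-yl lacks, with a lower number and the rest of the structure unchanged. No measurement at hand explains this step.

The compounds shown leave open which part of the change carries the step: ring size, the hydroxy group and the methyl group all enter together. Unsubstituted piperidin-1-yl, 4-hydroxypiperidin-1-yl and 3-methylpiperidin-1-yl would separate these parts, and an amine or a carboxylic acid in place of the hydroxy group would test what that position accepts.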